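Five-membered heteroaryl groups on the shared core

The compounds below may be only part of what the source reports. "The series", "measured", "known", "first", "only" and "open" are said of these compounds alone.

The measured compounds, in a functional assay on CCRF-CEM cells (Homo sapiens) for inhibition; a higher number here means a weaker inhibitor, a lower number a stronger inhibitor:
compound 1 `OC[C@H]1OC(n2cnc3c(-c4ccco4)ncnc32)[C@H](O)[C@@H]1O` gives 600 nM
compound 2 `OC[C@H]1OC(n2cnc3c(-c4cc[nH]c4)ncnc32)[C@H](O)[C@@H]1O` gives 1030 nM
compound 3 `OC[C@H]1OC(n2cnc3c(-c4ccc(O)cc4)ncnc32)[C@H](O)[C@@H]1O` gives 1250 nM

Compound 3 carries the highest number of the three in this assay. Its nearest neighbour is compound 2, and the two lie within the scatter of each other, so no order between them is claimed; its distance from compound 1 is larger, a 2.1-fold higher number from compound 1 to compound 3 (0.32 log units; beyond the scatter), a modest shift.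

Compound 4 `Cn1cccc1-c1ncnc2c1ncn2C1O[C@H](CO)[C@@H](O)[C@H]1O` arises from compound 3 by a single exchange: 1-methyl-1H-pyrrol-2-yl in place of 4-hydroxyphenyl on an aromatic carbon. Going by the values given here, two measured steps bear on this. The step from compound 2 to compound 3, a 1.2-fold higher number from compound 2 to compound 3 (0.08 log units; within the scatter), shows a five-membered ring with one hetero atom and a 4-hydroxyphenyl giving numbers within the scatter of each other. The step of a 2.1-fold higher number from compound 1 to compound 3 (0.32 log units; beyond the scatter) shows the other five-membered group with a lower number than the 4-hydroxyphenyl. Reversing the direction, the 1-methyl-1H-pyrrol-2-yl is therefore expected to give a number no higher than compound 3, and plausibly somewhat lower, about the size of those two steps. The expected step is a 1.7-fold lower number from compound 3 to compound 4 (0.22 log units; within the scatter). Compound 4 is estimated at 750 nM, with a range from 350 nM to 1600 nM.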

Compound 4, half-maximal inhibitory concentration: 2000 nM
Beside the measured number, compound 4's estimate is 2.7-fold (0.43 log units) below it; the whole stated range lies below it.
By their numbers in this assay, from the lowest: compounds 1, 2, 3 and 4 (each within the scatter of the next, the first and the last beyond it).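

In this assay, the 1-methyl-1H-pyrrol-2-yl group cannot be separated from the two groups closest to it, with a 1.6-fold higher number from compound 3 to compound 4 (0.20 log units; within the scatter) and a 1.9-fold higher number from compound 2 to compound 4 (0.29 log units; within the scatter). It is, however, clearly apart from the furan-2-yl, with a 3.3-fold higher number from compound 1 to compound 4 (0.52 log units; beyond the scatter), the largest step among the four compounds and still a modest one, so a five-membered aromatic ring at this position does not by itself secure the number of compound 1, and compound 4 is the case that goes against any such rule. Nothing measured here explains this difference between the two five-membered groups.

The compounds leave open whether the methyl group or the point of attachment of the ring sets compound 4 apart from compound 1, a question that an unsubstituted 1H-pyrrol-2-yl or a furan-3-yl at the same position could help to separate. Every group shown here is an aromatic ring, so it also remains open how an amine, a carboxylic acid or a longer alkyl chain on this aromatic carbon of the shared core would read in this assay.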